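Swapping 4-cyanophenyl for 2,4-difluorophenyl on the shared core

A few compounds are considered here, and "the series" means these few. Any claim that something is new, unique, unknown or untested is made for them only; others in the source may bear on it.

In a functional assay on ECV-304 cells (Homo sapiens) for cytotoxicity (a higher number here means a weaker inhibitor, a lower number a stronger inhibitor), compound 2 (`N#Cc1ccc(/C=C2\SC(=S)N(NS(=O)(=O)c3ccccc3)C2=O)cc1`) gives > 50000 nM as a limit, not a number. Compound 1 (`Cc1cccc(/C=C2\SC(=S)N(NS(=O)(=O)c3ccccc3)C2=O)c1`) gives > 50000 nM as a limit as well. Compound 3 (`O=C1/C(=C/c2ccc(C(F)(F)F)cc2)SC(=S)N1NS(=O)(=O)c1ccccc1`) likewise gives > 50000 nM as a limit. The series thus stands at the limit of > 50000 nM in this assay, at which 3 of the 3 values shown sit, and shows no readable number. Compound 4 (`O=C1/C(=C/c2ccc(F)cc2F)SC(=S)N1NS(=O)(=O)c1ccccc1`) is still unmeasured, and its change from compound 2 is 2,4-difluorophenyl in place of 4-cyanophenyl on a double-bonded chain carbon bound to a double-bonded ring carbon with the shared core kept. Going by the values given here, two measured steps bear on this: a step that the two limits leave unreadable from compound 1 to compound 2 and a step that the two limits leave unreadable from compound 2 to compound 3 are both without a readable size. The expected step, a number no higher from compound 2 to compound 4 (the limit leaves the size open), is none beyond the scatter, in either direction. The estimate for compound 4 is 50000 nM within an expected range of 20000 nM to 100000 nM and most likely a reported limit.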

Compound 4, half-maximal inhibitory concentration: > 50000 nM
Compound 4: no number, only a limit; the forecaster's own chance of this, stated with the estimate: 85%; the middle value sits exactly at the limit.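

Compound 4 gives > 50000 nM in this assay, a limit and not a number. Its steps from compound 1 and compound 2 cannot be read. The compounds shown leave open which change on the shared core, if any, would give a readable number: the limit of > 50000 nM in this assay, at which 4 of the 4 values shown sit.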